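The source may hold more compounds than are shown below. What is called first, only, known or untested is meant among the compounds shown, and "the series" means these compounds.

Three amides built on one shared core were run in a functional assay on HCC1937 cells (Homo sapiens) for antiproliferative activity, read by CCK-8 assay, with a stated time of 72 h; a higher number here means a weaker inhibitor, a lower number a stronger inhibitor. Compound 1 `O=C(Nc1cccc(-c2oc3cc(-c4ccc(F)cc4)ccc3c(=O)c2O)c1)c1ccc(F)cc1F` gives 6980 nM, compound 2 `O=C(Nc1cccc(-c2oc3cc(-c4ccc(F)cc4)ccc3c(=O)c2O)c1)c1ccc(Br)cc1` gives 8630 nM, and compound 3 `Cc1cc(C)cc(C(=O)Nc2cccc(-c3oc4cc(-c5ccc(F)cc5)ccc4c(=O)c3O)c2)c1` gives 4860 nM. Compound 3 thus stands at the low end of the three numbers, yet the steps of a 1.4-fold lower number from compound 1 to compound 3 (0.16 log units; within the scatter) and a 1.8-fold lower number from compound 2 to compound 3 (0.25 log units; within the scatter) both fall within the scatter, as does a 1.2-fold higher number from compound 1 to compound 2 (0.09 log units; within the scatter). Compound 4 `O=C(Nc1cccc(-c2oc3cc(-c4ccc(F)cc4)ccc3c(=O)c2O)c1)c1ccc([N+](=O)[O-])cc1` carries 4-nitrophenyl in place of 3,5-dimethylphenyl on a carbonyl carbon. Each measured step exchanges the aryl group on this same carbonyl carbon, and none shifted the number beyond the scatter, so no shift beyond the scatter is expected here either, giving an expected step of a 1.2-fold higher number from compound 3 to compound 4 (0.09 log units; within the scatter) in this assay. Compound 4 is therefore estimated at 6000 nM in this assay, between 2500 nM and 15000 nM.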

Compound 4, half-maximal inhibitory concentration: 5640 nM
Estimate against measurement, compound 4: 1.1-fold (0.03 log units) above; the measured number falls inside the stated range.
By their numbers in this assay, from the lowest: compounds 3, 4, 1 and 2 (each within the scatter of the next).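

In this assay, within the data shown here, a nitro group, which brings nitrogen and oxygen to an aryl ring that had so far carried only halogen or methyl substituents, leaves the number within the scatter, with steps of a 1.2-fold higher number from compound 3 to compound 4 (0.06 log units; within the scatter) and a 1.5-fold lower number from compound 2 to compound 4 (0.18 log units; within the scatter) and a 1.2-fold lower number from compound 1 to compound 4 (0.09 log units; within the scatter) all printed as such. The aryl group on this carbonyl carbon has thus been exchanged among four forms with no step beyond the scatter. Nothing shown accounts for this flat response. Still open, as far as these compounds go, is whether an aryl ring bearing an amine or a carboxylic acid, or a longer alkyl chain on this carbonyl carbon, would move the number beyond the scatter.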